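Moving the Trifluoromethyl Group on the Amide Ring

A few compounds are considered here, and "the series" means these few. Any claim that something is new, unique, unknown or untested is made for them only; others in the source may bear on it.

Compound 1, `COc1ccc(-c2cn3cc(C4=CCN(C(=O)c5ccccc5C(F)(F)F)CC4)ccc3n2)cc1OC`: 8110 nM
Compound 2, `COc1ccc(-c2cn3cc(C4=CCN(C(=O)C(C)(C)C)CC4)ccc3n2)cc1OC`: 7100 nM
Compound 3, `COc1ccc(-c2cn3cc(C4=CCN(S(=O)(=O)C5CCCCC5)CC4)ccc3n2)cc1OC`: 11100 nM

These three compounds share one core and differ only in the group attached to the ring nitrogen. In a functional assay on B16-F10 cells (Mus musculus) for antiproliferative activity, read by MTT assay, with a stated time of 48 h (a lower number here means a stronger inhibitor, a higher number a weaker inhibitor), compound 1 gives 8110 nM, the second highest of the three numbers. Its nearest neighbour is compound 2, a 1.1-fold lower number from compound 1 to compound 2 (0.06 log units; within the scatter); its furthest is compound 3, a 1.4-fold higher number from compound 1 to compound 3 (0.14 log units; within the scatter). Both steps fall within the usual scatter, and so does the remaining pair, a 1.6-fold higher number from compound 2 to compound 3 (0.19 log units; within the scatter), so none of the three can be ranked against the others.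

Compound 4, `COc1ccc(-c2cn3cc(C4=CCN(C(=O)c5cccc(C(F)(F)F)c5)CC4)ccc3n2)cc1OC`, differs from compound 1 in one place: 3-(trifluoromethyl)phenyl in place of 2-(trifluoromethyl)phenyl on a carbonyl carbon. Within the data shown here, no measured pair moves a trifluoromethyl group from one position of a ring to another, so there is no direct precedent. Among the measured compounds shown here, the steps that bear on it are the three exchanges of the whole group on the ring nitrogen, and each stayed within the scatter. Because a 1.1-fold lower number from compound 1 to compound 2 (0.06 log units; within the scatter) and a 1.4-fold higher number from compound 1 to compound 3 (0.14 log units; within the scatter) show that swapping out the entire group barely moves the number, a smaller rearrangement inside it is expected to do no more, giving an expected step of a 1.0-fold lower number from compound 1 to compound 4 (0.01 log units; within the scatter) in this assay. Compound 4 is therefore estimated at 8000 nM, with a likely range from 3500 nM to 18000 nM.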

Compound 4, half-maximal inhibitory concentration: 7890 nM
Beside the measured number, compound 4's estimate is 1.0-fold (0.01 log units) above it; low and high end bracket the measured number.
By their numbers in this assay, from the lowest: compounds 2, 4, 1 and 3 (each within the scatter of the next).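

Moving the trifluoromethyl group, from 2-(trifluoromethyl)phenyl to 3-(trifluoromethyl)phenyl on the carbonyl carbon, keeps the same atoms and only joins them differently, and in this assay this gives a 1.0-fold lower number from compound 1 to compound 4 (0.01 log units; within the scatter), so the assay does not separate these two placements. The comparisons with very different groups on the ring nitrogen add to this picture, with a 1.1-fold higher number from compound 2 to compound 4 (0.05 log units; within the scatter) and a 1.4-fold lower number from compound 3 to compound 4 (0.15 log units; within the scatter), which means that the tert-butyl amide, the cyclohexylsulfonyl compound and both trifluoromethyl isomers all remain unranked against one another. Nothing measured here speaks to why the numbers stay so close.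

What remains open is whether any group at this site can produce a step beyond the scatter at all, since every exchange shown so far stays within it. A carboxylic acid or a primary amine on the phenyl ring in place of trifluoromethyl, or a longer chain in place of tert-butyl on the carbonyl carbon, would test whether this site is as insensitive as these four compounds suggest.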